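Furan-3-yl in place of furan-2-yl on the shared core

The source may hold more compounds than are shown below. What is called first, only, known or untested is meant among the compounds shown, and "the series" means these compounds.

Measured compounds:
compound 1 `CC(=O)C1=C(C)NC(=O)NC1c1ccoc1` 15%
compound 2 `CCCC(=O)C1=C(C)NC(=O)NC1c1ccoc1` 22%
compound 3 `CCNC(=O)C1=C(C)NC(=O)NC1c1ccco1` 1%

In an assay on membranes from HEK293 cells for displacement of a labelled ligand from adenosine receptor A2b (Homo sapiens), read by scintillation counting, with a stated time of 30 min, tested at 1 uM (a higher number here means more inhibition at the concentration tested (going by the name of the read-out), a lower number less inhibition), compound 3 gives the lowest number of the three, with compound 1 closest at 15% and compound 2 furthest at 22%, both gaps beyond the scatter. Compound 4 `CCNC(=O)C1=C(C)NC(=O)NC1c1ccoc1` differs from compound 3 by furan-3-yl in place of furan-2-yl on a saturated ring carbon. Going by the values given here, no measured step covers this change directly; the only measured step, a number 7 percentage points higher from compound 1 to compound 2 (within the scatter), concerns a different part of the molecule. Compound 1 and compound 2 do carry furan-3-yl, but they differ from compound 3 in more than one place, so their values give only a loose hint. For compound 4 a small rise is expected, a number 7 percentage points higher from compound 3 to compound 4 (within the scatter), with an estimate of 8% between 0% and 25%.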

Compound 4, a percentage reported as inhibition, at one concentration (the size of the read-out at that concentration, not a potency): 2%
Beside the measured number, compound 4's estimate is 6 percentage points above it; the range from low to high includes it.
By their numbers in this assay, from the lowest: compounds 3 and 4 (each within the scatter of the next); then compounds 1 and 2 (each within the scatter of the next).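

In this assay furan-3-yl in place of furan-2-yl on a saturated ring carbon gives a number 1 percentage points higher from compound 3 to compound 4 (within the scatter) so with the ethylamino group on the carbonyl carbon, the two furans cannot be told apart. With furan-3-yl held fixed, ethylamino in place of propyl gives a number 20 percentage points lower from compound 2 to compound 4 (beyond the scatter) and ethylamino in place of methyl gives a number 13 percentage points lower from compound 1 to compound 4 (beyond the scatter) so here the carbonyl substituent matters more than the furan attachment point. No evidence on hand explains these steps.

Going by these compounds, whether the two furans also match with propyl on the carbonyl carbon remains open. So does the effect of a phenyl ring in place of the furan.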